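A few compounds are considered here, and "the series" means these few. Any claim that something is new, unique, unknown or untested is made for them only; others in the source may bear on it.

Compound 1 `CCCC1C(=O)N(C)c2cnc(Nc3ccc(S(N)(=O)=O)cc3)nc2N1C`: 206 nM
Compound 2 `CN1C(=O)C(c2cccc(C(F)(F)F)c2)N(C)c2nc(Nc3ccc(S(N)(=O)=O)cc3)ncc21`: 2710 nM
Compound 3 `CN1C(=O)C(c2ccccc2Cl)N(C)c2nc(Nc3ccc(S(N)(=O)=O)cc3)ncc21`: 129 nM

In an assay on Sf9 cells for inhibition of serine/threonine-protein kinase 4 (Homo sapiens), read by luminescence and ADP-Glo, with a stated time of 1 h, in the presence of a further agent that is not named here (on this read-out lower numbers stand for stronger inhibition and higher numbers for weaker inhibition), compound 1 gives 206 nM, the second highest of the three numbers; compound 3 sits nearest to it and compound 2 furthest away. Compound 4 `CN1C(=O)C(c2cccs2)N(C)c2nc(Nc3ccc(S(N)(=O)=O)cc3)ncc21` differs from compound 1 in one place: thiophen-2-yl in place of propyl on a saturated ring carbon. Going by the values given here, two measured steps bear on this change. a 13-fold higher number from compound 1 to compound 2 (1.12 log units; beyond the scatter), a large step, whereas a 1.6-fold lower number from compound 1 to compound 3 (0.20 log units; within the scatter), which stays within the scatter. An aromatic ring on this saturated ring carbon has thus either left the number where it was or raised it sharply. Thiophen-2-yl carries no trifluoromethyl group and is a five-membered aromatic ring with one hetero atom, so compound 4 is expected to stay close to compound 1, a 1.2-fold higher number from compound 1 to compound 4 (0.08 log units; within the scatter). The estimated value for compound 4 is 250 nM, with a range from 80 nM to 800 nM.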

Compound 4, half-maximal inhibitory concentration: 88 nM
Compound 4: the middle estimate sits 2.8-fold (0.45 log units) above what was measured, and the stated range covers the measured number.
By their numbers in this assay, from the lowest: compounds 4, 3 and 1 (each within the scatter of the next, the first and the last beyond it); then compound 2.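

Thiophen-2-yl is the only replacement of propyl in this assay that lowers the number beyond the scatter (a 2.3-fold lower number from compound 1 to compound 4 (0.37 log units; beyond the scatter)). It stands level with 2-chlorophenyl (a 1.5-fold lower number from compound 3 to compound 4 (0.17 log units; within the scatter)) and far from 3-(trifluoromethyl)phenyl (a 31-fold lower number from compound 2 to compound 4 (1.49 log units; beyond the scatter)), so two of the three aromatic rings on this saturated ring carbon keep the number low, while compound 2 goes against that. Nothing given here explains these differences. As far as these compounds go, how an amine, a carboxylic acid or a longer chain on this carbon would read remains open, as does whether a furan-2-yl ring would track thiophen-2-yl.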